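The source may hold more compounds than are shown below. What is called first, only, known or untested is meant among the compounds shown, and "the series" means these compounds.

In a functional assay on MCF7 cells (Homo sapiens) for inhibition, read by sulforhodamine B assay (on this read-out lower numbers stand for stronger inhibition and higher numbers for weaker inhibition), two compounds sharing one core have been measured. Compound 1 (`O=C1C=C(N2CCC2)C(=O)c2c1nc1n2[C@H]2OC[C@@H](O)[C@H]2OC1`), with azetidin-1-yl on a double-bonded ring carbon, gives > 16000 nM, which is a limit of the assay and not a number. Going by the values given here, compound 2 (`CCc1ccc(NC2=CC(=O)c3nc4n(c3C2=O)[C@H]2OC[C@@H](O)[C@H]2OC4)cc1`) gives 960 nM, the only true number so far. Putting (4-ethylphenyl)amino in place of azetidin-1-yl brought an at least 16-fold lower number from compound 1 to compound 2 (1.22 log units; beyond the scatter), a large step. On these data alone, that step starts from the limit of > 16000 nM in this assay, at which 1 of the 2 values shown sits, so its full size stays open.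

Compound 3 (`CCOc1ccc(NC2=CC(=O)c3nc4n(c3C2=O)[C@H]2OC[C@@H](O)[C@H]2OC4)cc1`) carries ethoxy in place of ethyl on an aromatic carbon, para to a large group (ethoxy in place of ethyl on an aromatic carbon). Among the compounds with values here, the one measured step replaced the whole group on the double-bonded ring carbon, so it bears only loosely on this smaller change, and no measured pair tests it directly. Compound 2 at 960 nM therefore serves as the anchor, and no shift beyond the scatter is expected in this assay, in either direction. The expected change is a 1.1-fold lower number from compound 2 to compound 3 (0.03 log units; within the scatter). The estimate for compound 3 is 900 nM, with an expected range from 300 nM to 2800 nM.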

Compound 3, half-maximal inhibitory concentration: 1430 nM
Estimate against measurement, compound 3: 1.6-fold (0.20 log units) below; the range from low to high includes it.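

In this assay, going from 4-ethylphenyl to 4-ethoxyphenyl gives a 1.5-fold higher number from compound 2 to compound 3 (0.17 log units; within the scatter), so at this place on the aromatic ring, para to a large group, adding one oxygen and one hydrogen-bond acceptor does not move the read-out beyond the scatter. Going by these compounds alone, the earlier compounds showed only what replacing the whole group on the double-bonded ring carbon could do, whereas this pair is the first to test a smaller change within that group, and the two values cannot be told apart. Nothing measured here gives a reason for this result.

On these data alone, whether a different group at this same place, such as an amine, a carboxylic acid or a longer chain like butoxy, would shift the number beyond the scatter remains open. Also open, as far as these compounds go, is how a plain phenylamino group with nothing on the ring, or a cyclic amine larger than azetidin-1-yl, would stand on the double-bonded ring carbon of the shared core.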